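The compounds below may be only part of what the source reports. "The series", "measured", "known", "first", "only" and "open" are said of these compounds alone.

Compound 1 `COc1cccc(-c2nc3cccc(-c4cc(OC)c(OC)c(OC)c4)c3o2)c1` and compound 2 `COc1cc(-c2cccc3nc(-c4ccc(Br)cc4)oc23)cc(OC)c1OC` share a common core and differ only in the aromatic group attached to it. In a functional assay on U-251 cells (Homo sapiens) for antiproliferative activity, read by MTT assay, with a stated time of 48 h (on this read-out lower numbers stand for stronger inhibition and higher numbers for weaker inhibition), compound 1 gives > 25000 nM, which is a limit of the assay rather than a number. In this assay compound 2 gives > 25000 nM, again a limit rather than a number. For the measured compounds named here, the only measured step, a step that the two limits leave unreadable from compound 1 to compound 2, is therefore unreadable, and the limit of > 25000 nM in this assay, at which 2 of the 2 values shown sit, shows where both values sit. Compound 2 thus stands at the limit, with nothing measured to rank it against.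

Compound 3 `COc1cc(-c2cccc3nc(-c4cccs4)oc23)cc(OC)c1OC` differs from compound 2 by thiophen-2-yl in place of 4-bromophenyl on an aromatic carbon. Going by the values given here, no measured step can guide this change: the one step in hand is unreadable, and both of its values are limits. The expectation is that compound 3 also shows no measurable inhibition in this assay, so that the step that the limit leaves unreadable from compound 2 to compound 3 is expected to be none beyond the scatter. Compound 3 is estimated at 30000 nM, between 10000 nM and 100000 nM, and is most likely to be reported only as a limit again.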

Compound 3, half-maximal inhibitory concentration: 3000 nM
Beside the measured number, compound 3's estimate is 10-fold (1.00 log units) above it; measured number below the stated range.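

The group on the aromatic carbon of the five-membered ring, next to the ring nitrogen and next to the ring oxygen, can clearly move the result in this assay. Thiophen-2-yl in place of 4-bromophenyl gives an at least 8.3-fold lower number from compound 2 to compound 3 (0.92 log units; beyond the scatter), and thiophen-2-yl in place of 3-methoxyphenyl gives an at least 8.3-fold lower number from compound 1 to compound 3 (0.92 log units; beyond the scatter). For the compounds shown here, these are the first readable steps at this position, though each gives only a minimum size, and with one compound carrying a real number, nothing ties the change to any single feature of thiophen-2-yl, while most of the values remain limits: the limit of > 25000 nM in this assay, at which 2 of the 3 values shown sit.

From the compounds shown here alone, it remains open whether the gain belongs to thiophen-2-yl alone or also appears with another five-membered aromatic ring, such as furan-2-yl, or with a plain phenyl ring carrying no substituent. Also open, going by these compounds, is how a group bearing an amine or a carboxylic acid would read at this same position, which would show how much change the position tolerates.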